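A few compounds are considered here, and "the series" means these few. Any claim that something is new, unique, unknown or untested is made for them only; others in the source may bear on it.

Measured compounds:
- compound 1 `COc1cc(-c2nn(-c3ccc(NC(=O)c4ccc(Cl)c(C(F)(F)F)c4)cc3)cc2-c2ccncc2)ccc1Cl`: 1560 nM
- compound 2 `O=C(Nc1ccc(-n2cc(-c3ccncc3)c(-c3ccc(Cl)c(O)c3)n2)cc1)c1ccc(Cl)c(Cl)c1`: 1450 nM

In a functional assay on LOX IMVI cells (Homo sapiens) for antiproliferative activity, read by sulforhodamine B assay, with a stated time of 48 h (on this read-out higher numbers stand for weaker inhibition and lower numbers for stronger inhibition), compound 2 holds the lower of the two numbers, but compound 1 sits within the scatter of it, so no order can be read from the pair. Compound 3 `O=C(Nc1ccc(-n2cc(-c3ccncc3)c(-c3ccc(Cl)c(O)c3)n2)cc1)c1ccc(Cl)c(C(F)(F)F)c1` follows from compound 2 by trifluoromethyl in place of chloro on an aromatic carbon. Among the compounds with values here, no step between measured compounds covers this change. Compound 1 already carries the trifluoromethyl group together with another change, and its value of 1560 nM is close to compound 2. For compound 3 the step of a 1.0-fold lower number from compound 2 to compound 3 (0.02 log units; within the scatter) is expected to stay inside the scatter, with an estimate of 1400 nM and a range from 600 nM to 3500 nM.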

Compound 3, half-maximal inhibitory concentration: 360 nM
Compound 3: the middle estimate sits 3.9-fold (0.59 log units) above what was measured, and the stated range ends above it.
By their numbers in this assay, from the lowest: compound 3; then compounds 2 and 1 (each within the scatter of the next).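

In this assay, this position responds to the change: trifluoromethyl in place of chloro, ortho to a chloro group, gives a 4.0-fold lower number from compound 2 to compound 3 (0.61 log units; beyond the scatter). With trifluoromethyl present in both compounds, hydrogen in place of methyl on an oxygen on an aromatic ring gives a 4.3-fold lower number from compound 1 to compound 3 (0.64 log units; beyond the scatter), so the close values of compound 1 and compound 2 concealed two separate single-place steps. Nothing available accounts for either step.

Going by these compounds, whether a nitrile or a methyl at this position would match trifluoromethyl remains open. Also open, on these data alone, is whether an amine could replace the oxygen-bearing group on the other aromatic ring without raising the number.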